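The compounds below may be only part of what the source reports. "The series", "measured", "known", "first", "only" and "open" are said of these compounds alone.

In a functional assay on A549 cells (Homo sapiens), read by MTT assay, with a stated time of 72 h (a lower number here means a stronger inhibitor, a higher number a weaker inhibitor), compound 1 (`Nc1nc(N)c2c(-c3ccsc3)cn([C@@H]3O[C@H](CO)[C@@H](O)[C@H]3O)c2n1`) gives > 100000 nM, which is a limit and not a number. Compound 2 (`Nc1nc(N)c2c(-c3cc4ccccc4o3)cn([C@@H]3O[C@H](CO)[C@@H](O)[C@H]3O)c2n1`) gives > 20000 nM, also a limit. Compound 3 (`Cc1nc(N)c2c(-c3ccsc3)cn([C@@H]3O[C@H](CO)[C@@H](O)[C@H]3O)c2n1`) gives > 20000 nM, likewise a limit. Among the measured compounds shown here, no compound in this small set therefore has a measured potency in this assay.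

Compound 4 (`COc1nc(N)nc2c1c(-c1ccsc1)cn2[C@@H]1O[C@H](CO)[C@@H](O)[C@H]1O`) keeps the thiophen-3-yl group of compound 1 and carries methoxy in place of amino on an aromatic carbon, (methoxy in place of amino on an aromatic carbon).

For the measured compounds named here, two measured steps bear on this change. The closer one also removes an amino group, with methyl entering: a step that the two limits leave unreadable from compound 1 to compound 3. The other exchanges thiophen-3-yl for 1-benzofuran-2-yl: a step that the two limits leave unreadable from compound 1 to compound 2. Neither has a readable size, so they support no firm direction. Since neither change produced a numerical value, compound 4 is expected to remain near the same limits, most likely as a limit itself. The expected change is an at least 2.0-fold lower number from compound 1 to compound 4 (0.30 log units; that floor lies within the scatter). For compound 4 the estimated value is 50000 nM, with an expected range from 10000 nM to 100000 nM.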

Compound 4, half-maximal inhibitory concentration: > 100000 nM
Compound 4 gave a limit, no number (the forecaster's own chance of this, stated with the estimate: 80%); middle value at least 2.0-fold (0.30 log units) away from the limit.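

In this assay compound 4 gives > 100000 nM, a limit and not a number. Compound 1 gives > 100000 nM, also a limit, and the step from compound 1 to compound 4 cannot be read. The compounds shown leave open whether amino, methyl or methoxy on the shared core makes any difference to potency.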